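The source may report more compounds than this note shows. Statements on the series, on what has been measured and on what is new or still open speak of the compounds shown alone.

Measured so far:
compound 1, `CC(C)=CCC/C(C)=C\C=N/NC(=O)Nc1nnc(-c2ccc(C)cc2)o1`, 300 mg/kg
compound 2, `CC(C)=CCC/C(C)=C\C=N/c1nnc(-c2ccccc2)o1`, 100 mg/kg

In a functional assay on the whole organism (strain albino) with Mus musculus as the target, in the maximal electroshock model, with a stated time of 4 h (on this read-out lower numbers stand for an effect already at smaller amounts and higher numbers for an effect only at larger amounts of compound), compound 1 gives 300 mg/kg, the highest of the two numbers in hand. Among the measured compounds shown here, compound 2, the only other measured compound, gives a lower number in this assay, and that gap lies beyond the scatter; the two differ in more than one place, so the values are taken as they stand, without a single-change step.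

Compound 3, `COc1ccc(-c2nnc(NC(=O)N/N=C\C=C(\C)CCC=C(C)C)o2)cc1`, is not yet measured. It differs from compound 1 as follows: methoxy in place of methyl on an aromatic carbon. For the measured compounds named here, no measured pair shows this change, so nothing in the data gives its direction or size. The step from compound 1 to compound 3 in this assay is expected to stay within the scatter, no change at the digits printed from compound 1 to compound 3 (within the scatter). Compound 3 is therefore estimated at 300 mg/kg in this assay, with a range of 150 mg/kg to 600 mg/kg.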

Compound 3, minimum effective dose: 300 mg/kg
Estimate against measurement, compound 3: no gap at the digits printed; measured number inside the range.
By their numbers in this assay, from the lowest: compound 2; then compounds 1 and 3 (each within the scatter of the next).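

In this assay, the series gains its first single-change step, and it reads no change at the digits printed from compound 1 to compound 3 (within the scatter). At this position, para to a large group on the six-membered aromatic ring, 4-methylphenyl and 4-methoxyphenyl therefore cannot be told apart on this read-out, although methoxy adds one heavy atom and one hydrogen-bond acceptor. No measurement here bears on why this change leaves the number within the scatter.

One step at one position does not show how far this tolerance extends. A carboxylic acid, a dimethylamino group or a longer alkoxy chain such as butoxy remains an open case at this position, and these compounds cannot say whether any of them would move the number beyond the scatter.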